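From (4-methylpiperazin-1-yl)carbonyl to methoxycarbonyl on the shared core

The compounds below may be only part of what the source reports. "The series", "measured", "known", "first", "only" and "open" are said of these compounds alone.

Of the compounds shown here, two have been read so far in a functional assay on KB cells (Homo sapiens) for inhibition, read by sulforhodamine B assay, with a stated time of 72 h; a higher number here means a weaker inhibitor of growth, a lower number a stronger inhibitor of growth: compound 1 (`CN1CCN(C(=O)/C=C/c2ccncc2-c2ccc3ccccc3c2)CC1`) and compound 2 (`O=C(/C=C/c1ccncc1-c1ccc2cc[nH]c2c1)N1CCOCC1`). In this assay compound 1 gives > 10000 nM, which is a limit and not a number. In this assay compound 2 gives > 10000 nM, which is likewise a limit. Among the compounds with values here, the position so far is the limit of > 10000 nM in this assay, at which 2 of the 2 values shown sit. Within the data shown here, compound 1 therefore has no measured number of its own, and no step between measured compounds is available to set a scale.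

Compound 3 (`COC(=O)/C=C/c1ccncc1-c1ccc2ccccc2c1`) keeps the core of compound 1 and carries methoxy in place of 4-methylpiperazin-1-yl on a carbonyl carbon. No step beyond the scatter is expected in this assay, and the data favour no direction. This expectation rests only on compound 1 with its limit of > 10000 nM. The expected step is a step that the limit leaves unreadable from compound 1 to compound 3. The estimate for compound 3 is 12000 nM, with an expected range from 4000 nM to 30000 nM. Another report as a limit is the likeliest outcome.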

Compound 3, concentration for 50% growth inhibition: 6730 nM
Compound 3: middle estimate off by 1.8-fold (0.25 log units), on the high side, within the range that was stated.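

In this assay compound 3 gives 6730 nM, the only number among the compounds shown, so methoxycarbonyl on the shared core gives a reading inside the range of this assay. Compound 1 gives > 10000 nM, which is a limit. Methoxy in place of 4-methylpiperazin-1-yl on a carbonyl carbon therefore reads as an at least 1.4-fold lower number from compound 1 to compound 3 (0.17 log units; that floor lies within the scatter), which is a floor and not a measured size, so this position can now be said to admit a measurable value, but the change cannot yet be said to lower the number by more than the usual scatter.

Most of the readings in this series remain limits, and a single number gives no scale for this position: the limit of > 10000 nM in this assay, at which 2 of the 3 values shown sit. Still open, on these data alone, is whether a carboxylic acid, a longer ester such as ethoxycarbonyl, or a small amine amide such as dimethylamino on the same carbonyl carbon would give a number near that of compound 3 or return to a limit.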